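Phenethyl for phenyl on the shared core

The compounds below may be only part of what the source reports. "The series", "measured", "known", "first", "only" and "open" are said of these compounds alone.

Measured so far in a physicochemical assay for solubility, with a stated time of 18 h, at pH 7.4; on this read-out higher numbers stand for higher solubility and lower numbers for lower solubility

compound 1 `COc1cccc(CNCCCNc2ccnc3cc(-c4ccc(F)cc4)ccc23)c1O` gives 32000 nM
compound 2 `COc1cccc(CNCCCNc2ccnc3cc(-c4ccccc4)ccc23)c1O` gives 32000 nM

For the measured compounds named here, on these numbers compound 2 stands level with compound 1 at the digits given, and no other measured compound is available for comparison. Going by the values given here, the only measured step, hydrogen in place of fluoro on an aromatic carbon, is no change at the digits printed from compound 1 to compound 2 (within the scatter) and lies within the scatter.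

The next compound is compound 3 `COc1cccc(CNCCCNc2ccnc3cc(CCc4ccccc4)ccc23)c1O` which keeps the core of compound 2 and carries phenethyl in place of phenyl on an aromatic carbon. The measured step involves a different group, so it bears on this change only indirectly. Among the compounds with values here, no measured compound carries phenethyl, and the data hold no direct precedent for this replacement.

The starting point is therefore compound 2 at 32000 nM with a wide range to reflect the thin evidence. The expected change in this assay is a 1.1-fold lower number from compound 2 to compound 3 (0.06 log units; within the scatter) and no step beyond the scatter is expected, in either direction.

The estimate for compound 3 is 28000 nM and its value is expected to fall between 12000 nM and 45000 nM in this read-out.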

Compound 3, solubility: 4200 nM
Beside the measured number, compound 3's estimate is 6.7-fold (0.82 log units) above it; the whole stated range lies above it.
By their numbers in this assay, from the lowest: compound 3; then compounds 1 and 2 (each within the scatter of the next).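

In this assay this position proves sensitive to what it carries: hydrogen in place of fluoro on the phenyl left the number unmoved (no change at the digits printed from compound 1 to compound 2 (within the scatter)), but phenethyl in place of phenyl gives a 7.6-fold lower number from compound 2 to compound 3 (0.88 log units; beyond the scatter), and phenethyl in place of 4-fluorophenyl gives the same size of step (a 7.6-fold lower number from compound 1 to compound 3 (0.88 log units; beyond the scatter)). Phenyl and phenethyl have the same ring, the same count of hydrogen-bond donors and acceptors and no net charge, so the only counted difference is in carbon, 6 heavy atoms against 8. No measurement at hand accounts for the step.

With a single linked group on this position, the compounds shown cannot tell whether the number falls progressively with chain length, as benzyl or the longer 3-phenylpropyl would show, or whether phenethyl is a special case. Also open, from the compounds shown here alone, are whether fluoro on the ring of phenethyl remains as silent as it is on phenyl, and how a carboxylic acid or an amine at the end of the two-carbon chain would read in this assay.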